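The compounds below may be only part of what the source reports. "The series", "measured", "known", "first", "only" and "open" are said of these compounds alone.

Compound 1 `Cc1cccc(C(=O)/C=C/c2ccc3c(c2)B(O)OC3)c1`: 8.56 ug/mL
Compound 2 `O=C(/C=C/c1ccc2c(c1)B(O)OC2)c1ccco1`: > 10 ug/mL
Compound 3 `O=C(/C=C/c1ccc2c(c1)B(O)OC2)c1ccccc1O`: > 10 ug/mL

The three measured compounds share one core and differ only in the group on the carbonyl carbon. In an ADME assay on L929 cells (Mus musculus) for cytotoxicity, read by resazurin assay, with a stated time of 72 h (a lower number here means a stronger inhibitor, a higher number a weaker inhibitor), compound 1 gives 8.56 ug/mL. For compound 2 the value > 10 ug/mL is a limit of this assay and not a number. For compound 3 the value > 10 ug/mL is likewise a limit. Compound 3 thus stands only at a limit, (the limit of > 10 ug/mL in this assay, at which 2 of the 3 values shown sit), so its place relative to the others is not fixed. All the measured compounds offer are the step of an at least 1.1-fold higher number from compound 1 to compound 3 (0.06 log units; that floor lies within the scatter) and the step that the two limits leave unreadable from compound 2 to compound 3, with an at least 1.1-fold higher number from compound 1 to compound 2 (0.06 log units; that floor lies within the scatter) running alongside. The unmeasured compound 4 `Cn1cccc1C(=O)/C=C/c1ccc2c(c1)B(O)OC2` differs from compound 3 in one place: 1-methyl-1H-pyrrol-2-yl in place of 2-hydroxyphenyl on a carbonyl carbon. Going by the values given here, no measured step changes this group in the same way, and each step touching compound 3 is a floor within the scatter or unreadable, so no shift beyond the scatter is expected in this assay, and a further limit is thought likely. The step this estimate means is a number no higher from compound 3 to compound 4 (the limit leaves the size open), an expectation rather than a measurement. Compound 4 is expected to give about 10 ug/mL, between 5 ug/mL and 20 ug/mL.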

Compound 4, half-maximal inhibitory concentration: > 10 ug/mL
Compound 4: no number, only a limit; the forecaster's own chance of this, stated with the estimate: 65%; the middle value lies on the limit itself.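

With compound 4, a group bearing a ring nitrogen, 1-methyl-1H-pyrrol-2-yl, joins furan-2-yl and 2-hydroxyphenyl on the carbonyl carbon without giving a number in this assay. Going by these compounds alone, the one step that can be read is an at least 1.1-fold higher number from compound 1 to compound 4 (0.06 log units; that floor lies within the scatter), so this change shows no separation from the 3-methylphenyl group of compound 1 beyond the scatter, and the steps that link compound 4 to compound 2 and compound 3 cannot be read. What this position now shows is a gathering of three different groups at one limit: the limit of > 10 ug/mL in this assay, at which 3 of the 4 values shown sit.

Where compound 2, compound 3 and compound 4 lie relative to one another remains open. As far as these compounds go, it is also open whether an amine or a carboxylic acid on the carbonyl-bound ring would give a readable number in this assay.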